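Same Chloro Change Carried From One Core to Another

The source may hold more compounds than are shown below. What is called first, only, known or untested is meant among the compounds shown, and "the series" means these compounds.

Compound 1, `Cc1[nH]c2ccc([N+](=O)[O-])cc2c1C1(c2c(C)[nH]c3ccc([N+](=O)[O-])cc23)C(=O)Nc2ccccc21`: 940 nM
Compound 2, `COC(=O)c1ccc2[nH]cc(C3(c4c[nH]c5ccc(C(=O)OC)cc45)C(=O)Nc4ccccc43)c2c1`: 980 nM
Compound 3, `Cc1[nH]c2ccc([N+](=O)[O-])cc2c1C1(c2c(C)[nH]c3ccc([N+](=O)[O-])cc23)C(=O)Nc2ccc(Cl)cc21`: 1230 nM

All three were measured in a functional assay on SK-N-SH cells (Homo sapiens) for cytotoxicity, read by MTT assay, with a stated time of 48 h; a higher number here means a weaker inhibitor, a lower number a stronger inhibitor. Compound 3 differs from compound 1 in one place, (chloro in place of hydrogen on an aromatic carbon), and that step came out as a 1.3-fold higher number from compound 1 to compound 3 (0.12 log units; within the scatter). Compound 2 differs from compound 1 in more than one place; the difference between the two cores is not broken down here. In this assay compound 2 and compound 1 give numbers that lie within the scatter of each other.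

Compound 4, `COC(=O)c1ccc2[nH]cc(C3(c4c[nH]c5ccc(C(=O)OC)cc45)C(=O)Nc4ccc(Cl)cc43)c2c1`, is not yet measured. Going by the values given here, it differs from compound 2 by chloro in place of hydrogen on an aromatic carbon, the same change as the one from compound 1 to compound 3, at the same place. Because the earlier step of a 1.3-fold higher number from compound 1 to compound 3 (0.12 log units; within the scatter) stayed within the scatter, compound 4 is expected to sit close to compound 2, with a step of about a 1.2-fold higher number from compound 2 to compound 4 (0.09 log units; within the scatter). Compound 4 is therefore estimated at 1200 nM, likely between 600 nM and 2500 nM.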

Compound 4, half-maximal inhibitory concentration: 9900 nM
Compound 4: the middle estimate sits 8.3-fold (0.92 log units) below what was measured; the measured number lies above the stated range.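

In this assay, chloro in place of hydrogen on an aromatic carbon did not behave alike on the two cores, giving a 10-fold higher number from compound 2 to compound 4 (1.00 log units; beyond the scatter). Set beside the earlier step, this shows that the result did not carry over from the core of compound 1 to the core of compound 2: the same change on two cores in this assay, a 1.3-fold higher number (0.12 log units; within the scatter) from compound 1 to compound 3 and a 10-fold higher number (1.00 log units; beyond the scatter) from compound 2 to compound 4, 7.7-fold (0.89 log units) apart, beyond the scatter of two such steps. It does not show why the two cores differ, and a single pair on each core sets no rule for the series.

The compounds shown leave open whether the larger step belongs to chloro alone or would also appear with fluoro or methoxy at the same place on the core of compound 2. They also leave open how an amine there would behave on either core.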